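Swapping the aldehyde-derived aryl group on a triazine hydrazone

This account rests on a few compounds, and the source may have more. Where it says the series, first, only, none or still open, it means among the compounds named here.

Measured compounds:
Compound 1, `NS(=O)(=O)c1ccc(Nc2nc(N/N=C/c3ccc(C(F)(F)F)cc3)nc(Nc3ccccc3)n2)cc1`: 2620 nM
Compound 2, `Cc1nn(-c2ccccc2)cc1/C=N/Nc1nc(Nc2ccccc2)nc(Nc2ccc(S(N)(=O)=O)cc2)n1`: 2000 nM

Both compounds were tested in a functional assay on EKVX cells (Homo sapiens) for inhibition, read by sulforhodamine B assay, with a stated time of 48 h; a higher number here means a weaker inhibitor of growth, a lower number a stronger inhibitor of growth. Going by the values given here, compound 2 sits at 2000 nM, and the only comparison available is with compound 1, where the change amounts to a 1.3-fold lower number from compound 1 to compound 2 (0.12 log units; within the scatter), so the two cannot be told apart on these numbers.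

Compound 3, `NS(=O)(=O)c1ccc(Nc2nc(N/N=C/c3ccccn3)nc(Nc3ccccc3)n2)cc1`, keeps the shared core and changes only the group attached to the carbon with a double bond to nitrogen: pyridin-2-yl in place of 3-methyl-1-phenyl-1H-pyrazol-4-yl on a carbon with a double bond to nitrogen. Among the compounds with values here, the one measured step at this same position, a 1.3-fold lower number from compound 1 to compound 2 (0.12 log units; within the scatter), replaced one aryl group with another and moved the number by less than the scatter. On that single precedent, the expected step from compound 2 to compound 3 is a 1.3-fold higher number from compound 2 to compound 3 (0.10 log units; within the scatter), that is, no change beyond the scatter. The estimate for compound 3 is therefore 2500 nM, with a range from 800 nM to 8000 nM.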

Compound 3, concentration for 50% growth inhibition: 710 nM
The estimate for compound 3 lay 3.5-fold (0.55 log units) above the measured number, and the stated range ends above it.
By their numbers in this assay, from the lowest: compound 3; then compounds 2 and 1 (each within the scatter of the next).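

In this assay, the group on the carbon with a double bond to nitrogen does affect the number: pyridin-2-yl gives a 2.8-fold lower number from compound 2 to compound 3 (0.45 log units; beyond the scatter) and a 3.7-fold lower number from compound 1 to compound 3 (0.57 log units; beyond the scatter). Both steps lie beyond the scatter, so the earlier swap of one aryl group for another, which stayed within it, does not hold for every group at this place. Nothing available on these compounds gives a reason for the lower number.

The compounds shown leave open what goes with this drop, as the change from compound 2 to compound 3 both brings in a ring nitrogen and reduces the group from 12 heavy atoms to 6. A plain phenyl group at this place would help separate the ring nitrogen from the size of the group.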